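The source may report more compounds than this note shows. Statements on the series, on what has been measured and on what is new or still open speak of the compounds shown alone.

Measured so far:
Compound 1, `CC(C(=O)NCc1ccc(C(F)(F)F)nc1-c1ccsc1)c1ccc(NS(C)(=O)=O)c(F)c1` — in an assay on CHO cells for antagonist activity at transient receptor potential cation channel subfamily V member 1 (Homo sapiens), read by FLIPR (a higher number here means a weaker inhibitor, a lower number a stronger inhibitor), compound 1 gives 2 nM.
Compound 2, `CC(C(=O)NCc1ccc(C(F)(F)F)nc1Cc1ccccc1)c1ccc(NS(C)(=O)=O)c(F)c1` — in this assay compound 2 gives 141 nM.

Going by the values given here, compound 2 holds the higher of these two numbers; the single step leading to it, a 71-fold higher number from compound 1 to compound 2 (1.85 log units; beyond the scatter), is large. Compound 3, `CC(C(=O)NCc1ccc(C(F)(F)F)nc1/C=C/c1ccccc1)c1ccc(NS(C)(=O)=O)c(F)c1`, differs from compound 2 in one place: 2-phenylethenyl in place of benzyl on an aromatic carbon. Among the compounds with values here, the one measured step touches the same position and shows that the group there can shift the number strongly, but it does not show which way the new group will move it. A modest gain in potency is therefore expected, a 2.4-fold lower number from compound 2 to compound 3 (0.37 log units; beyond the scatter), with wide uncertainty. Compound 3 is estimated to give 60 nM, between 10 nM and 400 nM.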

Compound 3, inhibition constant: 2.2 nM
Compound 3: middle estimate off by 27-fold (1.44 log units), on the high side; the measured number lies below the stated range.
By their numbers in this assay, from the lowest: compounds 1 and 3 (each within the scatter of the next); then compound 2.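

In this assay, the group on this aromatic carbon strongly sets the number: 2-phenylethenyl in place of benzyl gives a 64-fold lower number from compound 2 to compound 3 (1.81 log units; beyond the scatter), although both groups carry the same six-membered aromatic ring. The ring alone therefore does not decide the result, and 2-phenylethenyl in place of thiophen-3-yl gives a 1.1-fold higher number from compound 1 to compound 3 (0.04 log units; within the scatter). No measurement shown here explains the gap between the benzyl and 2-phenylethenyl compounds. Still open, going by these compounds, is how 2-phenylethyl, the same chain without its double bond, would behave at this position.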